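A phenylethenyl arm replaces the 3-chlorophenyl

This account rests on a few compounds, and the source may have more. Where it says the series, first, only, none or still open, it means among the compounds named here.

Going by the values given here, in a functional assay on ECa-109 cells (Homo sapiens) for cytotoxicity, read by MTT assay, with a stated time of 72 h (on this read-out higher numbers stand for weaker inhibition and lower numbers for stronger inhibition), compound 2 `O=C1C(=Cc2cccc(Cl)c2)C(=O)N(c2ccc(Cl)cc2)N1c1ccc(Cl)cc1` gives 22600 nM, the only number so far. Compound 1 `CN(C)c1ccc(C=C2C(=O)N(c3ccc(Cl)cc3)N(c3ccc(Cl)cc3)C2=O)cc1` reaches only a limit, > 128000 nM. Compound 3 `O=C1C(=C/C=C/c2ccccc2)C(=O)N(c2ccc(Cl)cc2)N1c1ccc(Cl)cc1` carries 2-phenylethenyl in place of 3-chlorophenyl on a double-bonded chain carbon bound to a double-bonded ring carbon. Among the compounds with values here, one measured step bears on this swap: an at least 5.6-fold lower number from compound 1 to compound 2 (0.75 log units; beyond the scatter), made at the same place and starting from that limit. It gives no direction for the new group, so the expected change, a 1.1-fold lower number from compound 2 to compound 3 (0.05 log units; within the scatter), is not expected to lie beyond the scatter. For compound 3 the estimate is 20000 nM, with an expected range of 6000 nM to 70000 nM.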

Compound 3, half-maximal inhibitory concentration: 9900 nM
Beside the measured number, compound 3's estimate is 2.0-fold (0.31 log units) above it; the measured number falls inside the stated range.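

In this assay, replacing the 3-chlorophenyl with 2-phenylethenyl gives a 2.3-fold lower number from compound 2 to compound 3 (0.36 log units; beyond the scatter), so this place on a double-bonded chain carbon bound to a double-bonded ring carbon accepts an arm with a double bond outside aromatic rings and no chlorine. Set against 4-(dimethylamino)phenyl, the same arm gives an at least 12-fold lower number from compound 1 to compound 3 (1.11 log units; beyond the scatter). That step starts from a limit, so it is only a bound: the limit of > 128000 nM in this assay, at which 1 of the 3 values shown sits.

The compounds shown leave open whether the added double bond or the lost chlorine carries the step from compound 2 to compound 3. They also leave open how an unsubstituted phenyl or a saturated 2-phenylethyl chain would read at this place.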